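Amino in Place of Methoxy: Weak Cytotoxicity Expected to Persist

A few compounds are considered here, and "the series" means these few. Any claim that something is new, unique, unknown or untested is made for them only; others in the source may bear on it.

The measured compounds:
Compound 1, `COc1ccccc1Nc1nc(-c2cccc(F)c2)nc2ccc(F)cc12`: in a functional assay on HL-60 cells (Homo sapiens) for cytotoxicity, read by MTT assay, with a stated time of 48 h (on this read-out higher numbers stand for weaker inhibition and lower numbers for stronger inhibition), compound 1 gives > 50000 nM, a limit of the assay rather than a number.
Compound 2, `Oc1cccc(Nc2nc(-c3cccc(F)c3)nc3ccc(F)cc23)c1`: in this assay compound 2 gives > 50000 nM, again only a limit.
Compound 3, `Oc1ccccc1Nc1nc(-c2cccc(F)c2)nc2ccc(F)cc12`: in this assay compound 3 gives 44400 nM.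

Compound 1 thus stands at the limit, the point at which two of the three values sit (the limit of > 50000 nM in this assay, at which 2 of the 3 values shown sit). Compound 4, `Nc1ccccc1Nc1nc(-c2cccc(F)c2)nc2ccc(F)cc12`, differs from compound 1 in one place: amino in place of methoxy on an aromatic carbon.

Among the compounds with values here, two measured steps bear on it. Removing the methyl from the oxygen gives an at least 1.1-fold lower number from compound 1 to compound 3 (0.05 log units; that floor lies within the scatter), and moving the hydroxyl gives an at least 1.1-fold lower number from compound 2 to compound 3 (0.05 log units; that floor lies within the scatter), while a step that the two limits leave unreadable from compound 1 to compound 2. Within the data shown here, none of these steps is readable beyond the scatter, and no measured compound carries an amino group, so the new change has no direct precedent.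

Compound 4 is therefore expected to stay close to compound 1, with an at least 1.1-fold lower number from compound 1 to compound 4 (0.04 log units; that floor lies within the scatter). The estimate for compound 4 is 45000 nM, with a range from 15000 nM to 100000 nM, and a fair chance that the assay again reports only a limit.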

Compound 4, half-maximal inhibitory concentration: 41300 nM
The estimate for compound 4 lay 1.1-fold (0.04 log units) above the measured number; measured number inside the range.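

In this assay, compound 4 carries an amino group on the aromatic carbon ortho to a large group, where compound 3 carries hydroxy, and this exchange gives a 1.1-fold lower number from compound 3 to compound 4 (0.03 log units; within the scatter). Amino and hydroxy at this place therefore cannot be told apart in this assay. Against the other two compounds the change reads only as a floor, with an at least 1.2-fold lower number from compound 1 to compound 4 (0.08 log units; that floor lies within the scatter) and an at least 1.2-fold lower number from compound 2 to compound 4 (0.08 log units; that floor lies within the scatter), and neither floor fixes the size of the step: the limit of > 50000 nM in this assay, at which 2 of the 4 values shown sit.

The compounds shown leave open whether any group on this carbon can move the number beyond the scatter. They do not tell how a dimethylamino group, an acetamido group or a carboxylic acid would read there.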